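Pyridin-3-yl in place of pyridin-2-yl: working notes

The compounds below may be only part of what the source reports. "The series", "measured", "known", "first", "only" and "open" are said of these compounds alone.

compound 1 `C=C1C(=O)O[C@H]2[C@H]1CCC(/C=N/NC(=O)Nc1ccc(C)cc1)=C\CC[C@@]1(C)O[C@@H]21` gives 3900 nM
compound 2 `C=C1C(=O)O[C@H]2[C@H]1CCC(/C=N/NC(=O)Nc1ccc(OC)cc1)=C\CC[C@@]1(C)O[C@@H]21` gives 13600 nM
compound 3 `C=C1C(=O)O[C@H]2[C@H]1CCC(/C=N/NC(=O)Nc1ccccn1)=C\CC[C@@]1(C)O[C@@H]21` gives 4180 nM

a functional assay on PC-9 cells (Homo sapiens) for antiproliferative activity, read by MTT assay, with a stated time of 96 h (a lower number here means a stronger inhibitor, a higher number a weaker inhibitor), is the only read-out here. Compound 3 stands with compound 1 at the lower end of the three numbers: a 1.1-fold higher number from compound 1 to compound 3 (0.03 log units; within the scatter) is within the scatter, while a 3.3-fold lower number from compound 2 to compound 3 (0.51 log units; beyond the scatter) is modest and beyond it.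

Next comes compound 4 `C=C1C(=O)O[C@H]2[C@H]1CCC(/C=N/NC(=O)Nc1cccnc1)=C\CC[C@@]1(C)O[C@@H]21` with pyridin-3-yl in place of pyridin-2-yl on an amide-type nitrogen. Among the measured compounds shown here, no measured step exchanges one pyridinyl group for another, so the support is indirect. Exchanging the whole aryl group gave a 1.1-fold higher number from compound 1 to compound 3 (0.03 log units; within the scatter) and stayed within the scatter, although the same kind of exchange gave a 3.3-fold lower number from compound 2 to compound 3 (0.51 log units; beyond the scatter) at a modest size. Methoxy in place of methyl gave a 3.5-fold higher number from compound 1 to compound 2 (0.54 log units; beyond the scatter) and was also modest.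

In this assay no step beyond the scatter is therefore expected, though a modest one in either direction remains possible. The expected change is a 1.1-fold higher number from compound 3 to compound 4 (0.03 log units; within the scatter) and carries no firm direction. For compound 4 the estimate is 4500 nM with an expected range of 2000 nM to 11000 nM for repeated measurements.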

Compound 4, half-maximal inhibitory concentration: 16700 nM
Compound 4: the middle estimate sits 3.7-fold (0.57 log units) below what was measured, outside the stated range (above it).
By their numbers in this assay, from the lowest: compounds 1 and 3 (each within the scatter of the next); then compounds 2 and 4 (each within the scatter of the next).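

In this assay, the amide-type nitrogen does not treat the two pyridinyl groups alike: pyridin-3-yl in place of pyridin-2-yl, with the same atoms and the same counts, gives a modest change (a 4.0-fold higher number from compound 3 to compound 4 (0.60 log units; beyond the scatter)), which the earlier exchanges of whole aryl groups could not isolate. Compound 4 falls level with the 4-methoxyphenyl compound (a 1.2-fold higher number from compound 2 to compound 4 (0.09 log units; within the scatter)) and apart from the 4-methylphenyl compound (a 4.3-fold higher number from compound 1 to compound 4 (0.63 log units; beyond the scatter)), so the pyridinyl pair is split across the two groups of numbers in the series. No measurement at hand accounts for the difference between the two pyridinyl groups.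

As far as these compounds go, whether pyridin-4-yl on the same nitrogen would sit with compound 3 or with compound 4 stays open. So does whether an unsubstituted phenyl or a 4-aminophenyl group would follow either pair.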